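The compounds below may be only part of what the source reports. "The series", "measured", "known", "first", "only" and "open" are said of these compounds alone.

In an ADME assay on RAW264.7 cells (Mus musculus) for cytotoxicity, read by MTT assay, with a stated time of 24 h (a higher number here means that more compound is tolerated, a lower number that less compound is tolerated), compound 1 (`C=C(C(=O)O)[C@@H]1C[C@@]2(C)C(=CC1=O)C=C[C@H](O)[C@@H]2C`) gives > 50000 nM, which is a limit of the assay and not a number. Compound 2 (`C=C(C(=O)O)[C@@H]1C[C@@]2(C)C(=CC1=O)C=C[C@H](OC(=O)CC/C=C/C)[C@@H]2C`) gives > 50000 nM, which is also only a limit. Within the data shown here, both compounds therefore stand at the limit of > 50000 nM in this assay, at which 2 of the 2 values shown sit, and the one measured comparison is a step that the two limits leave unreadable from compound 1 to compound 2. Compound 3 (`C/C=C/CCC(=O)O[C@H]1C=CC2=CC(=O)[C@H](/C(C=O)=C\OC)C[C@]2(C)[C@H]1C`) has not yet been measured. It differs from compound 2 on a saturated ring carbon: 1-formyl-2-methoxyethenyl in place of 1-carboxyethenyl on a saturated ring carbon. The measured step concerns an oxygen on a saturated carbon, not the 1-carboxyethenyl group, so it gives no size for this exchange. A large move is therefore not expected, although any readable move would have to be toward less compound tolerated. The expected change is an at least 1.2-fold lower number from compound 2 to compound 3 (0.09 log units; that floor lies within the scatter). Compound 3 is estimated at 40000 nM, with an expected range from 12000 nM to 100000 nM.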

Compound 3, half-maximal cytotoxic concentration: > 50000 nM
Compound 3 was reported as a limit (the forecaster's own chance of this, stated with the estimate: 60%); middle value at least 1.2-fold (0.09 log units) from the limit.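

Compound 3 is also reported only as a limit, so no step can be read from compound 2 to compound 3 in this assay, and all three compounds stand together: the limit of > 50000 nM in this assay, at which 3 of the 3 values shown sit.

The compounds shown leave open how much of any of them is tolerated, and whether 1-formyl-2-methoxyethenyl in place of 1-carboxyethenyl changes that at all.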